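Methyl on the Outer Ring: From Compound 2 to Compound 4

A few compounds are considered here, and "the series" means these few. Any claim that something is new, unique, unknown or untested is made for them only; others in the source may bear on it.

Compounds with measurements:
- compound 1 `CC1=C(C(=O)OCc2ccccc2)C(c2ccc(-c3ccccc3)cc2)NC(=S)N1CCCCCC(=O)O`: in a toxicity assay on MCF7 cells (Homo sapiens) for inhibition, with a stated time of 48 h (a higher number here means a weaker inhibitor of growth, a lower number a stronger inhibitor of growth), compound 1 gives "not determined" (no result reported)
- compound 2 `CC1=C(C(=O)OCc2ccccc2)C(c2ccc(-c3ccccc3)cc2)NC(=S)N1Cc1ccc(-c2nnn[nH]2)cc1`: in this assay compound 2 gives 140000 nM
- compound 3 `CC1=C(C(=O)OCc2ccccc2)C(c2ccc(-c3ccccc3)cc2)NC(=S)N1CCCCCc1nnn[nH]1`: in this assay compound 3 gives "not determined" (no result reported)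

Of the three measured compounds, only compound 2 carries a number in this assay; compound 1 and compound 3 give none, so compound 2 stands alone and cannot be ranked against either of them. Compound 2, with its value of 140000 nM, is a weak inhibitor of growth.

Compound 4 `CC1=C(C(=O)OCc2ccccc2)C(c2ccc(-c3ccccc3C)cc2)NC(=S)N1Cc1ccc(-c2nnn[nH]2)cc1` is the unmeasured analogue of compound 2. It differs in one place: methyl in place of hydrogen on an aromatic carbon. Within the data shown here, with no step between measured compounds available, the expected size of the step in this assay rests on the structural change alone. A single methyl added on an aromatic carbon of a six-membered aromatic ring of carbon only is a small change, and the step from compound 2 to compound 4 is expected to be a 1.2-fold lower number from compound 2 to compound 4 (0.07 log units; within the scatter), that is, none beyond the scatter. Compound 4 is therefore estimated at 120000 nM, within a range from 45000 nM to 320000 nM.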

Compound 4, concentration for 50% growth inhibition: 160000 nM
Compound 4: the middle estimate sits 1.3-fold (0.12 log units) below what was measured; the measured number falls inside the stated range.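

In this assay, the change from phenyl to 2-methylphenyl gives a 1.1-fold higher number from compound 2 to compound 4 (0.06 log units; within the scatter), so a methyl on this aromatic carbon, ortho to a large group, leaves the number within the scatter. Among these compounds, this is the first step that can be read between two measured compounds, whereas the earlier compounds offered only a single number with nothing to set it against. Nothing measured here bears on why the step is this small.

The compounds shown leave open whether a different group at this position, such as an ethyl chain, a methoxy group, an amine or a carboxylic acid, would give a step beyond the scatter. They also leave open whether the same methyl would give a similar step on compound 1 or compound 3, which have no number to start from.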